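Two Bis-Arylidene Cyclohexanones, One Chloro-to-Methoxy Swap

The compounds below may be only part of what the source reports. "The series", "measured", "known", "first", "only" and "open" are said of these compounds alone.

Measured compounds:
compound 1, `COc1cccc(/C=C2\CCC/C(=C\c3ccccc3Cl)C2=O)c1OC`, 10300 nM
compound 2, `COc1ccccc1/C=C1\CCC/C(=C\c2cccc(OC)c2OC)C1=O`, > 20000 nM
compound 3, `COc1cccc(/C=C2\CCC/C(=C\c3ccc(O)c(Cl)c3)C2=O)c1OC`, 16800 nM

All three were tested in a functional assay on SW-620 cells (Homo sapiens) for cytotoxicity, read by MTT assay, with a stated time of 72 h; a higher number here means a weaker inhibitor, a lower number a stronger inhibitor. Compound 1 gives 10300 nM there. For compound 2 the result is a limit of the assay, not a number: the limit of > 20000 nM in this assay, at which 1 of the 3 values shown sits. Compound 3 gives 16800 nM.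

The change from compound 1 to compound 2 is methoxy in place of chloro on an aromatic carbon, and the step it made is an at least 1.9-fold higher number from compound 1 to compound 2 (0.28 log units; that floor lies within the scatter). The core of compound 3 differs from that of compound 1 by 3-chloro-4-hydroxyphenyl in place of 2-chlorophenyl on a double-bonded chain carbon bound to a double-bonded ring carbon, with the step of a 1.6-fold higher number from compound 1 to compound 3 (0.21 log units; within the scatter).

Compound 4, `COc1cc(/C=C2\CCC/C(=C\c3cccc(OC)c3OC)C2=O)ccc1O`, has not yet been measured. It differs from compound 3 by methoxy in place of chloro on an aromatic carbon. For the measured compounds named here, this is the same kind of change as the one from compound 1 to compound 2, though the place differs: in compound 4 the methoxy sits ortho to a hydroxy group and meta to a large group, whereas in compound 2 it sits ortho to a large group. For compound 4 the expected step is a 1.4-fold higher number from compound 3 to compound 4 (0.15 log units; within the scatter), resting on the earlier step of an at least 1.9-fold higher number from compound 1 to compound 2 (0.28 log units; that floor lies within the scatter). Compound 4 is therefore estimated at 24000 nM, with a real chance that the assay will again report only a limit.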

Compound 4, half-maximal inhibitory concentration: 8600 nM
Compound 4: middle estimate off by 2.8-fold (0.45 log units), on the high side, and the stated range ends above it.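

In this assay, replacing chloro with methoxy did not carry from one core to the other as a step of fixed size or direction, although each step taken alone stays within the scatter or has a floor within it: the same change on two cores in this assay, an at least 1.9-fold higher number (0.28 log units; that floor lies within the scatter) from compound 1 to compound 2 and a 2.0-fold lower number (0.29 log units; within the scatter) from compound 3 to compound 4, at least 3.7-fold (0.57 log units) apart, beyond the scatter of two such steps
Of the other new comparisons, a 1.2-fold lower number from compound 1 to compound 4 (0.08 log units; within the scatter) also stays within the scatter, so it sets no order between these two compounds, whereas an at least 2.3-fold lower number from compound 2 to compound 4 (0.36 log units; beyond the scatter) goes beyond the scatter, and a 2.0-fold lower number from compound 3 to compound 4 (0.29 log units; within the scatter) is the step that stands against the earlier one. Compound 2 is reported only as a limit of the assay, > 20000 nM, so both its steps are floors, and two pairs show neither a rule for the whole series nor why the steps part.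

The compounds shown leave open whether the difference goes with the place of the swap on the ring or with the rest of the core. They also leave open how an amine or a carboxylic acid at that same place, ortho to a hydroxy group, would read in this assay, and whether the methoxy step would hold on any third core.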